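The source may report more compounds than this note shows. Statements on the series, on what has been measured and on what is new or still open speak of the compounds shown alone.

Measured compounds:
- Compound 1 `COc1ccc(/C=C/c2cc(OC)cc(OC)c2/C=C/C(=O)Nc2cc(OC)c(OC)c(OC)c2)cc1`: 7010 nM
- Compound 2 `COc1ccc(/C=C/c2cc(OC)cc(OC)c2/C=C/C(=O)N2CCCCC2)cc1`: 6050 nM

Both values come from a functional assay on MCF7 cells (Homo sapiens) for inhibition, read by MTT assay, with a stated time of 48 h; a lower number here means a stronger inhibitor, a higher number a weaker inhibitor. Of the two numbers, compound 2 carries the lower one, but the gap to compound 1 lies within the scatter, so the two compounds cannot be told apart on these data. Among the measured compounds shown here, no single-point step between measured compounds is available here.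

Compound 3 `CCCCN(CCCC)C(=O)/C=C/c1c(/C=C/c2ccc(OC)cc2)cc(OC)cc1OC` has not yet been measured in this assay. It differs from compound 2 by dibutylamino in place of piperidin-1-yl on a carbonyl carbon. For the measured compounds named here, the only guide is the pair of measured compounds, whose values sit close together despite differing in the group on the carbonyl carbon. On that basis the step from compound 2 to compound 3 is expected to stay within the scatter, with no clear direction. Compound 3 is therefore estimated at 6500 nM, with a range from 2500 nM to 17000 nM, meaning an expected step of a 1.1-fold higher number from compound 2 to compound 3 (0.03 log units; within the scatter).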

Compound 3, half-maximal inhibitory concentration: 3990 nM
Compound 3: the middle estimate sits 1.6-fold (0.21 log units) above what was measured; low and high end bracket the measured number.
By their numbers in this assay, from the lowest: compounds 3, 2 and 1 (each within the scatter of the next).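

Replacing piperidin-1-yl with dibutylamino on the carbonyl carbon gives, in this assay, a 1.5-fold lower number from compound 2 to compound 3 (0.18 log units; within the scatter). This shows that, for this pair, the ring on the amide nitrogen can give way to two open butyl chains, with a larger count of heavy atoms, without a change that this assay can separate from scatter. No available evidence bears on the reason for this result.

The compounds shown leave open whether any group at this place moves the number beyond the scatter, for example morpholin-4-yl or a shorter diethylamino group on the carbonyl carbon. They also leave open what a carboxylic acid would do in place of the amide, or a dialkylamino group with chains longer than butyl.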